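The compounds below may be only part of what the source reports. "The series", "measured", "known", "first", "only" and "open" are said of these compounds alone.

Working notes on the series. Three aminothiophene ketones have been run in an assay on CHO cells for displacement of a labelled ligand from adenosine receptor A1 (Homo sapiens), read by scintillation counting, tested at 10 uM; on this read-out lower numbers stand for less inhibition and higher numbers for more inhibition at the one concentration tested (going by the name of the read-out): compound 1 `COc1ccc(-c2sc(N)c(C(=O)c3ccc(Cl)cc3)c2C)cc1` gives 1%, compound 2 `CC(C)(C)Cc1c(-c2ccc(Cl)c(Cl)c2)sc(N)c1C(=O)c1ccc(Cl)cc1` gives 1%, and compound 3 `COCCOc1ccc(-c2sc(N)c(C(=O)c3ccc(Cl)cc3)c2CC(C)(C)C)cc1` gives 1%. On these numbers compound 2 stands level with compounds 1 and 3; the values of the three lie within the usual scatter of one another, so no ordering can be drawn. Compound 4 `CC(C)(C)Cc1c(-c2ccsc2)sc(N)c1C(=O)c1ccc(Cl)cc1` is not yet measured. It differs from compound 2 as follows: thiophen-3-yl in place of 3,4-dichlorophenyl on an aromatic carbon. With all three measured compounds at the same low level in this assay, no step beyond the scatter is expected from compound 2 to compound 4. Compound 4 is accordingly expected at about 2%, in the range -6% to 12%, an estimated step of a number 1 percentage points higher from compound 2 to compound 4 (within the scatter).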

Compound 4, a percentage reported as inhibition, at one concentration (the size of the read-out at that concentration, not a potency): 2%
The estimate for compound 4 equals the measured number at the digits printed; the range from low to high includes it.
By their numbers in this assay, from the lowest: compounds 1, 2, 3 and 4 (each within the scatter of the next).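

In this assay, thiophen-3-yl in place of 3,4-dichlorophenyl on the aromatic carbon next to the ring sulfur gives a number 1 percentage points higher from compound 2 to compound 4 (within the scatter). Going by these compounds alone, this is the first one-place comparison, and it shows that exchanging this six-membered ring and its two chlorines for a five-membered ring with one sulfur moves the read-out by no more than the scatter. No available evidence bears on this result. As far as these compounds go, whether an amine or a carboxylic acid at this aromatic carbon would lift the read-out stays open. So does the effect of a longer chain in place of the neopentyl group.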